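Aryl Group Changes in a Zeta-Carotene Desaturase Inhibitor Series

The source may report more compounds than this note shows. Statements on the series, on what has been measured and on what is new or still open speak of the compounds shown alone.

compound 1, `CCC(COc1cccc(C(F)(F)F)c1)OC(=O)NCc1ccccc1`: in an assay for inhibition of zeta-carotene desaturase, chloroplastic/chromoplastic (Capsicum annuum), using a Dixon plot, with a stated time of 8 h (on this read-out lower numbers stand for stronger inhibition and higher numbers for weaker inhibition), compound 1 gives > 100000 nM, a limit of the assay
compound 2, `CCC(COc1cccc(Br)c1)OC(=O)NCc1ccccc1`: in this assay compound 2 gives > 100000 nM, a limit of the assay
compound 3, `CCOC(=O)c1cccc(OCC(CC)OC(=O)NCc2ccccc2)c1`: in this assay compound 3 gives > 100000 nM, a limit of the assay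

Compound 2 therefore stands at the assay limit, as do the two other values shown, all three sitting at the limit of > 100000 nM in this assay, at which 3 of the 3 values shown sit. The steps a step that the two limits leave unreadable from compound 1 to compound 2, a step that the two limits leave unreadable from compound 1 to compound 3 and a step that the two limits leave unreadable from compound 2 to compound 3 consequently have no readable size or direction. Compound 4, `CCC(COc1cc(Cl)cc(Cl)c1)OC(=O)NCc1ccccc1`, differs from compound 2 by 3,5-dichlorophenyl in place of 3-bromophenyl on an oxygen on a saturated carbon. Within the data shown here, no measured step bears readably on this change. The account expects the step that the limit leaves unreadable from compound 2 to compound 4 to leave compound 4 at or near the limit. Compound 4 is expected to give about 150000 nM in this assay, within 30000 nM to 1000000 nM.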

Compound 4, half-maximal inhibitory concentration: > 100000 nM
Compound 4 was reported as a limit; the forecaster's own chance of this, stated with the estimate: 85%; the middle value lies beyond the limit too.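

Compound 4 also gives only a limit, like compound 2, and the step between compound 2 and compound 4 cannot be read: the limit of > 100000 nM in this assay, at which 4 of the 4 values shown sit. The compounds shown leave open how these aryl groups rank against one another on the shared core.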